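A few compounds are considered here, and "the series" means these few. Any claim that something is new, unique, unknown or untested is made for them only; others in the source may bear on it.

Measured so far in an assay on isolated protein for inhibition of Alpha glucosidase (Homo sapiens), read by spectrophotometry, with stated times of 15 min and 30 min; a lower number here means a stronger inhibitor, a higher number a weaker inhibitor:
compound 1 `COc1cc(/C=C2\SC(=O)NC2=O)ccc1OCN1C(=O)c2ccccc2C1=O`: 35100 nM
compound 2 `O=C1NC(=O)/C(=C/c2ccc(OCN3C(=O)c4ccccc4C3=O)c(Cl)c2)S1`: 21000 nM

Compound 1 shows the higher of the two numbers; compound 2 differs from it by a 1.7-fold lower number from compound 1 to compound 2 (0.22 log units; within the scatter). Compound 3 `COc1cc(/C=C2\SC(=S)NC2=O)ccc1OCN1C(=O)c2ccccc2C1=O` has not been measured. Relative to compound 1 it carries a group of 8 heavy atoms (4 carbon, 1 nitrogen, 1 oxygen, 2 sulfur; one five-membered non-aromatic ring with 2 hetero atoms) in place of a group of 8 heavy atoms (4 carbon, 1 nitrogen, 2 oxygen, 1 sulfur; one five-membered non-aromatic ring with 2 hetero atoms), on an aromatic carbon; the group that enters has one oxygen and two sulfur where the group that leaves has two oxygen and one sulfur, on the same five-membered non-aromatic ring. Within the data shown here, no measured step bears on this exchange; the only step at hand is the chloro-for-methoxy one, which lies within the scatter and concerns a different change. No step beyond the scatter is therefore expected. The expected step is a 1.2-fold lower number from compound 1 to compound 3 (0.07 log units; within the scatter). Compound 3 is estimated at 30000 nM, between 12000 nM and 80000 nM.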

Compound 3, half-maximal inhibitory concentration: 16100 nM
Beside the measured number, compound 3's estimate is 1.9-fold (0.27 log units) above it; the measured number falls inside the stated range.
By their numbers in this assay, from the lowest: compounds 3, 2 and 1 (each within the scatter of the next, the first and the last beyond it).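

In this assay, among these compounds, the five-membered ring is the first place to give a step beyond the scatter: one oxygen exchanged for sulfur, with the donor and acceptor counts unchanged, gives a modest step (a 2.2-fold lower number from compound 1 to compound 3 (0.34 log units; beyond the scatter)). The earlier chloro-for-methoxy change on the aromatic ring stayed within the scatter. No measurement at hand bears on the reason for this step.

Going by these compounds, whether the step holds when chloro stands in place of methoxy remains open. Also open, on these data alone, is how a carboxylic acid on the ring nitrogen would read here.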